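Fluoro to hydroxy on a chain: expected cytotoxicity of compound 4

The compounds below may be only part of what the source reports. "The series", "measured", "known", "first", "only" and "open" are said of these compounds alone.

Compound 1 `O=c1n(Cc2nc3nc(Cl)ccc3n2CCCCF)c2cnccc2n1C1CC1`: in an ADME assay on HeLa cells (Homo sapiens) for cytotoxicity, read by ATP content, with a stated time of 3 days (a lower number here means that less compound is tolerated, a higher number that more compound is tolerated), compound 1 gives > 50000 nM, a limit of the assay.
Compound 2 `O=c1n(Cc2cc3cnccc3n2CCCCF)c2cnccc2n1C1CC1`: compound 2 gives > 50000 nM, also a limit.
Compound 3 `CS(=O)(=O)CCCn1c(Cn2c(=O)n(C3CC3)c3ccncc32)cc2cc(Cl)ccc21`: compound 3 gives > 50000 nM, again a limit.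

Compound 2 thus stands where every measured compound stands, namely at the limit of > 50000 nM in this assay, at which 3 of the 3 values shown sit; no number separates it from the others. Compound 4 `O=c1n(Cc2cc3cnccc3n2CCCCO)c2cnccc2n1C1CC1` differs from compound 2 by hydroxy in place of fluoro on a saturated chain carbon, four bonds along the chain from an aromatic nitrogen. Among the measured compounds shown here, no measured pair shows the effect of this change, so only an expectation is possible: the step from compound 2 to compound 4 is expected to be none beyond the usual scatter, a number no higher from compound 2 to compound 4 (the limit leaves the size open). Compound 4 is therefore estimated at 50000 nM, within 20000 nM to 100000 nM, most likely reported again as a limit.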

Compound 4, half-maximal cytotoxic concentration: > 100000 nM
Compound 4 gave a limit, no number; the forecaster's own chance of this, stated with the estimate: 85%; at least 2.0-fold (0.30 log units) between middle value and limit.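

Compound 2 and compound 4 each gave only a limit, not a number, so the step between them cannot be read. The compounds shown leave open at what concentration any becomes cytotoxic, and whether hydroxy in place of fluoro shifts it.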